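The source may report more compounds than this note shows. Statements on the series, on what has been measured and on what is new or still open speak of the compounds shown alone.

Compound 1 `COc1cccc(-c2nc(SC)nc3sc(C(=O)NN)c(N)c23)c1` gives 8.5% in a functional assay on HEK293 cells for agonist activity at lutropin-choriogonadotropic hormone receptor (Homo sapiens), read by cAMP accumulation; a lower number here means a smaller maximal response, a higher number a larger maximal response. Compound 2 `COc1cccc(-c2nc(SC)nc3sc(C(=O)NNC(C)(C)C)c(N)c23)c1` gives 6% in this assay.

Compound 2 stands beside compound 1 on these numbers: the two are separated by a number 2.5 percentage points lower from compound 1 to compound 2 (within the scatter), a gap that lies within the scatter, so neither can be set above the other. Both show only a small maximal response in this assay.

Compound 3 `COc1cccc(-c2nc(SC)nc3sc(C(=O)OC(C)(C)C)c(N)c23)c1` differs from compound 2 by tert-butoxy in place of ((tert-butyl)amino)amino on a carbonyl carbon. Among the measured compounds shown here, the only measured step, a number 2.5 percentage points lower from compound 1 to compound 2 (within the scatter), touched the same side chain, exchanging hydrogen for tert-butyl on an amine nitrogen, and left the response essentially unchanged. For the measured compounds named here, the step to compound 3 removes the hydrazide linkage altogether and puts a tert-butoxy on the carbonyl carbon, a change of a different kind, for which no direct precedent exists among the measured compounds. Going by the values given here, with both known values low and the one known step flat, the expectation for compound 3 in this assay is a step of a number 1 percentage points higher from compound 2 to compound 3 (within the scatter), that is, no movement beyond the scatter. Compound 3 is therefore estimated at 7%, within a range from 0% to 20%.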

Compound 3, largest response reached (reported as efficacy), in percent of the reference or control that the assay uses: 23.8%
For compound 3 the middle estimate is 16.8 percentage points below the measured one; the whole stated range lies below it.
By their numbers in this assay, from the lowest: compounds 2 and 1 (each within the scatter of the next); then compound 3.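

On the carbonyl carbon in this assay, tert-butoxy in place of ((tert-butyl)amino)amino gives a number 17.8 percentage points higher from compound 2 to compound 3 (beyond the scatter) and tert-butoxy in place of aminoamino gives a number 15.3 percentage points higher from compound 1 to compound 3 (beyond the scatter) in a step of the same direction. The earlier pair had shown only that adding tert-butyl to the hydrazide left the response within the scatter, whereas these steps show that the response at this position does depend on what is attached to the carbonyl carbon. Since compound 2 and compound 3 both carry a tert-butyl group, that group alone does not set them apart, and the step goes with the change from a nitrogen link to an oxygen link, though no available evidence explains the rise.

Going by these compounds, whether the response needs the ester oxygen, the tert-butyl group or both stays open, and a methyl ester, a plain tert-butyl amide or the free carboxylic acid at this carbonyl would help to separate them. On these data alone, it is also open whether a step of this size would hold with other groups on the shared core, and whether any group here can take the response beyond a modest level.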